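Chloro for Fluoro on a Second Core

A few compounds are considered here, and "the series" means these few. Any claim that something is new, unique, unknown or untested is made for them only; others in the source may bear on it.

Compound 1 `Fc1ccc(CSc2nnc(-c3cnccn3)s2)cc1` and compound 2 `Clc1ccc(CSc2nnc(-c3cnccn3)s2)cc1` share one core. In a functional assay on BGC-823 cells (Homo sapiens) for antiproliferative activity, read by MTT assay, with a stated time of 48 h (on this read-out lower numbers stand for stronger inhibition and higher numbers for weaker inhibition), compound 1 gives 29300 nM, while compound 2 gives 13400 nM. The change between them is chloro in place of fluoro on an aromatic carbon, and its measured step was a 2.2-fold lower number from compound 1 to compound 2 (0.34 log units; beyond the scatter). Compound 3 `Fc1ccc(CSc2nnc(-c3cnccn3)n2-c2ccccc2)cc1` is built on a different core; the difference between the two cores is not broken down here. In this assay compound 3 gives 27200 nM. Compound 4 `Clc1ccc(CSc2nnc(-c3cnccn3)n2-c2ccccc2)cc1` differs from compound 3 by the same change, (chloro in place of fluoro on an aromatic carbon), at the same place. Going by the values given here, the expectation for compound 4 rests on the single measured example of this change, a 2.2-fold lower number from compound 1 to compound 2 (0.34 log units; beyond the scatter). A step of similar size is expected, a 2.0-fold lower number from compound 3 to compound 4 (0.30 log units; within the scatter). Compound 4 is therefore estimated at 13500 nM, with a range from 6500 nM to 27000 nM.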

Compound 4, half-maximal inhibitory concentration: 27700 nM
Compound 4: middle estimate off by 2.1-fold (0.31 log units), on the low side; measured number outside the range, above it.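

On the core of compound 3, chloro in place of fluoro gives a 1.0-fold higher number from compound 3 to compound 4 (0.01 log units; within the scatter) in this assay, so on this core the change shows no effect that can be told from scatter. Even so, the steps on the two cores cannot be told apart from each other: the same change on two cores in this assay, a 2.2-fold lower number (0.34 log units; beyond the scatter) from compound 1 to compound 2 and a 1.0-fold higher number (0.01 log units; within the scatter) from compound 3 to compound 4, 2.2-fold (0.35 log units) apart, within the scatter of two such steps. Going by these compounds alone, this shows neither that the gain seen on the first core carries over to the second nor that it is lost, since each core offers only one pair.

Going by these compounds, it remains open how a bromo or methoxy group at the same place would read on either core. Whether an amine there would shift the number on one core but not the other is also unknown.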